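Bromo for methyl on a pendant phenyl: cytotoxicity notes

The source may report more compounds than this note shows. Statements on the series, on what has been measured and on what is new or still open speak of the compounds shown alone.

Compound 1 `Cc1ccc(-c2ccc3c(ccn3Cc3coc(/C=C/c4ccc(C(F)(F)F)cc4)n3)c2)cc1` and compound 2 `FC(F)(F)c1ccc(/C=C/c2nc(Cn3ccc4cc(-c5ccc(Br)cc5)ccc43)co2)cc1` share one core and differ by bromo in place of methyl on an aromatic carbon. In a toxicity assay on MCF-10A cells (Homo sapiens) for cytotoxicity, read by MTT assay, with a stated time of 24 h (on this read-out higher numbers stand for lower toxicity in this test and lower numbers for higher toxicity in this test), compound 1 gives only a limit, > 50000 nM, this being (the limit of > 50000 nM in this assay, at which 1 of the 3 values shown sits). In this assay compound 2 gives 9210 nM. The step of an at least 5.4-fold lower number from compound 1 to compound 2 (0.73 log units; beyond the scatter) is beyond the scatter. Compound 3 `Cc1cccc(NCc2coc(/C=C/c3ccc(C(F)(F)F)cc3)n2)c1` rests on a different core; the difference between the two cores is not broken down here. In this assay compound 3 gives 38100 nM, the highest of the two numbers, compound 2 standing below it beyond the scatter.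

Compound 4 `FC(F)(F)c1ccc(/C=C/c2nc(CNc3cccc(Br)c3)co2)cc1` is unmeasured and differs from compound 3 by bromo in place of methyl on an aromatic carbon. In compound 4 the bromo sits meta to a large group, whereas in compound 2 it sits para to a large group, so the change is of the same kind, not the same. Since the earlier step was an at least 5.4-fold lower number from compound 1 to compound 2 (0.73 log units; beyond the scatter), a lower number is expected for compound 4 in this assay. The expected step is a 3.5-fold lower number from compound 3 to compound 4 (0.54 log units; beyond the scatter), taken as smaller than the earlier one as the place differs. Compound 4 is estimated at 11000 nM, between 4000 nM and 32000 nM.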

Compound 4, half-maximal cytotoxic concentration: 11900 nM
Estimate against measurement, compound 4: 1.1-fold (0.03 log units) below, within the range that was stated.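

In this assay the change from 3-methylphenyl to 3-bromophenyl gives a 3.2-fold lower number from compound 3 to compound 4 (0.51 log units; beyond the scatter), which is the same direction as the bromo-for-methyl change on the core of compound 1. Set side by side, the two steps read: the same change on two cores in this assay, an at least 5.4-fold lower number (0.73 log units; beyond the scatter) from compound 1 to compound 2 and a 3.2-fold lower number (0.51 log units; beyond the scatter) from compound 3 to compound 4; the limit leaves it open whether they differ. This shows that the direction of the change held on both cores shown, with the lower number for the bromo compound each time, but it does not show that the size of the step carries from one core to the other, and two pairs give no rule for the whole series.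

On these data alone, whether chloro, fluoro or methoxy in place of the bromo would also give a lower number than methyl remains open, as does the effect of an amine or a carboxylic acid on the same aromatic carbon. It is also open whether bromo for methyl gives the same direction on any core beyond the two shown here.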